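The source may hold more compounds than are shown below. What is called first, only, known or untested is meant among the compounds shown, and "the series" means these compounds.

Compound 1 `O=C(NC1CCCN(Cc2ccc(F)c(F)c2)C1)c1ccc(-c2cscn2)cc1`: > 20000 nM (a limit)
Compound 2 `O=C(Nc1ccc(-c2nccs2)cc1)C1CCCN(Cc2ccc(F)c(F)c2)C1`: 800 nM

Both compounds were tested in a functional assay on A-375 cells (Homo sapiens) for activation, with a stated time of 3 days; on this read-out lower numbers stand for an effect already at smaller amounts and higher numbers for an effect only at larger amounts of compound. Compound 1 gives > 20000 nM, which is a limit of the assay and not a number. Within the data shown here, compound 2 gives 800 nM, the only true number so far, so it serves as the reference point for the next step.

Compound 3 `O=C(Nc1ccc(-c2cc[nH]c2)cc1)C1CCCN(Cc2ccc(F)c(F)c2)C1` keeps the rest of compound 2 and changes a single group: 1H-pyrrol-3-yl in place of 1,3-thiazol-2-yl on an aromatic carbon, para to a large group (1H-pyrrol-3-yl in place of 1,3-thiazol-2-yl on an aromatic carbon). Among the measured compounds shown here, the incoming group is again a five-membered aromatic ring, but no measured pair here differs in one place only, so the data offer no direct guide to the size of such a step.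

The expected step of a 1.9-fold higher number from compound 2 to compound 3 (0.27 log units; within the scatter) is modest and points toward a higher number, meaning a weaker effect, though a result within the scatter would be no surprise. A limit also occurs in this small set, and for compound 1 it is the limit of > 20000 nM in this assay, at which 1 of the 2 values shown sits. For compound 3 the expected value is 1500 nM, with an estimated range from 300 nM to 8000 nM.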

Compound 3, half-maximal effective concentration: 2610 nM
The estimate for compound 3 lay 1.7-fold (0.24 log units) below the measured number; the range from low to high includes it.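

Among these compounds, replacing 1,3-thiazol-2-yl with 1H-pyrrol-3-yl on an aromatic carbon, para to a large group, gives in this assay a 3.3-fold higher number from compound 2 to compound 3 (0.51 log units; beyond the scatter), the first comparison in this set between compounds that differ in one place only. This shows that the number responds to which five-membered aromatic ring sits at this position, even though both rings have 5 heavy atoms and no net charge. Sulfur leaves with this change, and the ring goes from 2 hydrogen-bond acceptors and no donor to 1 hydrogen-bond donor and no acceptor, but nothing measured here explains why the number rises.

From the compounds shown here alone, a single exchange cannot separate these differences, so it remains open whether the loss of sulfur, the gain of the ring's nitrogen-bound hydrogen or the change in acceptors matters most. Going by these compounds, it is also open how this position would respond to a group of another kind, such as a pyridine ring, a phenyl ring, an amine or a carboxylic acid, and whether any of these would give a lower number than the thiazole ring.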